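The compounds below may be only part of what the source reports. "The series", "measured", "known", "first", "only" and "open" are said of these compounds alone.

The measured compounds in a functional assay on HepG2 cells (Homo sapiens) for cytotoxicity, read by MTT assay, with a stated time of 72 h; a higher number here means that more compound is tolerated, a lower number that less compound is tolerated:

compound 1, `C[Se]/C(=N\C(=O)c1cccs1)NC(=O)c1cccs1`, 12500 nM
compound 2, `O=C(/N=C(/NC(=O)c1cccs1)[Se]Cc1ccccc1)c1cccs1`, 81500 nM
compound 3, `O=C(/N=C(/NC(=O)c1csc([N+](=O)[O-])c1)[Se]Cc1ccccc1)c1csc([N+](=O)[O-])c1`, 91600 nM

Compounds 1 and 2 share one core and differ in a single place: hydrogen in place of phenyl on a saturated chain carbon bound to a selenium atom. That change gave a 6.5-fold lower number from compound 2 to compound 1 (0.81 log units; beyond the scatter), so compound 1 is tolerated at a lower concentration than compound 2. Compound 3 carries a different core; how the two cores differ is not broken down here. Compound 3 and compound 2 lie within the scatter of each other in this assay, so nothing separates them.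

Compound 4, `C[Se]/C(=N\C(=O)c1csc([N+](=O)[O-])c1)NC(=O)c1csc([N+](=O)[O-])c1`, has not yet been measured. It stands to compound 3 as compound 1 stands to compound 2: hydrogen in place of phenyl on a saturated chain carbon bound to a selenium atom. The place is the same in both pairs, so this is the same change. Within the data shown here, its one measured example is a 6.5-fold lower number from compound 2 to compound 1 (0.81 log units; beyond the scatter), and on that a step of similar size is expected, namely a 6.5-fold lower number from compound 3 to compound 4 (0.82 log units; beyond the scatter). Among the measured compounds shown here, only one example of the change has been measured, so the range is kept wide. Compound 4 is expected to give 14000 nM in this assay, between 5000 nM and 40000 nM.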

Compound 4, concentration lethal to 50% of the cells: 10000 nM
Beside the measured number, compound 4's estimate is 1.4-fold (0.15 log units) above it; low and high end bracket the measured number.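

In this assay, replacing benzyl with methyl on the core of compound 3 gave a 9.2-fold lower number from compound 3 to compound 4 (0.96 log units; beyond the scatter), so the methyl compound is again the one tolerated at the lower concentration. Set beside the earlier case, the two steps do not differ: the same change on two cores in this assay, a 6.5-fold lower number (0.81 log units; beyond the scatter) from compound 2 to compound 1 and a 9.2-fold lower number (0.96 log units; beyond the scatter) from compound 3 to compound 4, 1.4-fold (0.15 log units) apart, within the scatter of two such steps. Among these compounds, the change therefore carried over from the core of compound 2 to the core of compound 3 with much the same size, but this rests on only two pairs in one cell line, and it does not show why the number falls or that the step would hold on any other core.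

Only methyl and benzyl appear at this place, so it stays open where an ethyl group, a longer chain or a chain ending in an amine would fall among these numbers. From the compounds shown here alone, it also stays open whether the step would survive on a core carrying a different group, such as a carboxylic acid, in place of the nitro groups of compound 3.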